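Hydrazone aryl swaps on a shared benzothiazole-free-named core

The compounds below may be only part of what the source reports. "The series", "measured", "known", "first", "only" and "open" are said of these compounds alone.

Measured so far in an assay on isolated protein for inhibition of Maltase-glucoamylase (Homo sapiens), with a stated time of 15 min; on this read-out higher numbers stand for weaker inhibition and lower numbers for stronger inhibition:
- compound 1 `COc1ccc(O)c(/C=N/NC(=O)c2ccc(-c3nc4ccccc4s3)cc2)c1`: 6500 nM
- compound 2 `O=C(N/N=C/c1cccnc1)c1ccc(-c2nc3ccccc3s2)cc1`: "not active" (no number reported)
- compound 3 `O=C(N/N=C/c1cccs1)c1ccc(-c2nc3ccccc3s2)cc1`: 8480 nM

Compound 1 gives the lowest of the two reported numbers in this assay. Its nearest neighbour is compound 3, and the step of a 1.3-fold higher number from compound 1 to compound 3 (0.12 log units; within the scatter) stays within the usual scatter, so the two compounds cannot be ranked against each other. Compound 2 was reported without a number and is simply recorded as not active in this assay.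

Compound 4 `O=C(N/N=C/c1cccc(O)c1O)c1ccc(-c2nc3ccccc3s2)cc1` is not yet measured. It differs from compound 1 at a single place: 2,3-dihydroxyphenyl in place of 2-hydroxy-5-methoxyphenyl on a carbon with a double bond to nitrogen

Within the data shown here, the only measured step that bears on this change is the one from compound 1 to compound 3, where a different aryl group entered on the same carbon with a double bond to nitrogen, and that step was within the scatter. Among the measured compounds shown here, no pair on hand isolates the move from 2-hydroxy-5-methoxyphenyl to 2,3-dihydroxyphenyl itself. On this basis the expected step of no change at the digits printed from compound 1 to compound 4 (within the scatter) is one of no change beyond the scatter, in neither direction. The estimate for compound 4 in this assay is therefore 6500 nM, with a range from 2500 nM to 17000 nM, the outcome of compound 2 being a reminder that a number may not be returned at all.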

Compound 4, half-maximal inhibitory concentration: 11200 nM
Estimate against measurement, compound 4: 1.7-fold (0.24 log units) below; low and high end bracket the measured number.
By their numbers in this assay, from the lowest: compounds 1, 3 and 4 (each within the scatter of the next).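

In this assay the 2,3-dihydroxyphenyl group on the carbon with a double bond to nitrogen gives a 1.7-fold higher number from compound 1 to compound 4 (0.24 log units; within the scatter) against 2-hydroxy-5-methoxyphenyl and a 1.3-fold higher number from compound 3 to compound 4 (0.12 log units; within the scatter) against thiophen-2-yl. This place now carries three groups that the read-out does not separate: two substituted phenyl rings and a thiophene, with the change in hydrogen-bond donor count between 2-hydroxy-5-methoxyphenyl and 2,3-dihydroxyphenyl arriving without a step beyond the scatter. Nothing measured on hand speaks to the reason for this result.

Still open, from the compounds shown here alone, is whether a group of another kind at this place, such as a 4-aminophenyl, a 4-carboxyphenyl or a saturated cyclohexyl, would move the number beyond the scatter in either direction. Also open, going by these compounds, is what sets compound 2, recorded as not active and so without a number to compare, apart from compounds 1, 3 and 4, and whether any change to the shared core would matter more than these aryl swaps.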